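The compounds below may be only part of what the source reports. "The series", "measured", "known", "first", "only" and "open" are said of these compounds alone.

Measured in an assay on CHO cells for inhibition of metabotropic glutamate receptor 1 (Rattus norvegicus); a lower number here means a stronger inhibitor, a higher number a weaker inhibitor:
compound 1 `Cc1c(C(=O)OC(C)(C)C)c[nH]c1C(=O)OC(C)(C)C`: 100 nM
compound 2 `Cc1c(C(=O)OC(C)(C)C)c[nH]c1C(=O)OCC1CC1`: 48 nM
compound 3 `Cc1c(C(=O)OC(C)(C)C)c[nH]c1C(=O)OCc1ccco1`: 1200 nM

Compound 3 holds the highest number of the three. The step of a 12-fold higher number from compound 1 to compound 3 (1.08 log units; beyond the scatter) is large, and the step of a 25-fold higher number from compound 2 to compound 3 (1.40 log units; beyond the scatter) larger still, so compound 3 lies furthest from compound 2 and nearest to compound 1.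

Compound 4 `Cc1c(C(=O)OC(C)(C)C)c[nH]c1C(=O)Sc1ccccn1` carries the change ((pyridin-2-yl)sulfanyl in place of (furan-2-yl)methoxy on a carbonyl carbon). Going by the values given here, no measured pair makes a change of this kind: every measured step alters the group beyond the ester oxygen, while here the sulfur replaces that oxygen and the ring sits directly on it. The measured steps do show that this side of the carbonyl governs the number: a 2.1-fold lower number from compound 1 to compound 2 (0.32 log units; beyond the scatter) was modest, whereas a 12-fold higher number from compound 1 to compound 3 (1.08 log units; beyond the scatter) and a 25-fold higher number from compound 2 to compound 3 (1.40 log units; beyond the scatter) were large. A change touching the same carbonyl is therefore expected to move this assay beyond the scatter. Because compound 3 stands at 1200 nM, the high end of the series, the more likely direction is downward, toward the numbers of compound 1 and compound 2, but the direction is not secured by any shown step. For compound 4 the expected step is a 4.0-fold lower number from compound 3 to compound 4 (0.60 log units; beyond the scatter), with compound 4 estimated at 300 nM within a wide range from 60 nM to 3000 nM.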

Compound 4, half-maximal inhibitory concentration: 3000 nM
Compound 4: middle estimate off by 10-fold (1.00 log units), on the low side; the range from low to high includes it.
By their numbers in this assay, from the lowest: compound 2; then compound 1; then compound 3; then compound 4.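

In this assay, the step with (pyridin-2-yl)sulfanyl in place of (furan-2-yl)methoxy on a carbonyl carbon is a 2.5-fold higher number from compound 3 to compound 4 (0.40 log units; beyond the scatter), so the number at this position also responds when the atom bound to the carbonyl carbon changes, not only when the group further out does. Against the two saturated groups the same (pyridin-2-yl)sulfanyl group gives a 30-fold higher number from compound 1 to compound 4 (1.48 log units; beyond the scatter) and a 63-fold higher number from compound 2 to compound 4 (1.80 log units; beyond the scatter), which makes compound 4 the weakest inhibitor of the four and places both groups that carry an aromatic ring at the high end of the series, with no compound shown going against that split. No measurement at hand explains these differences.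

Going by these compounds, the sulfur and the ring change together in the step to compound 4, so their separate shares stay open; a (pyridin-2-yl)methoxy group or a cyclopropylmethyl group on sulfur would separate them. Also open, on these data alone, is how an amide nitrogen or a carboxylic acid at this carbonyl carbon would read, and what the tert-butyl ester on the other carbonyl contributes, as it is the same in all four compounds.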